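The source may hold more compounds than are shown below. What is called first, only, known or untested is meant among the compounds shown, and "the series" means these compounds.

Measured so far in a functional assay on HepG2 cells (Homo sapiens) for antiproliferative activity, read by MTT assay, with a stated time of 48 h; on this read-out higher numbers stand for weaker inhibition and lower numbers for stronger inhibition:
- compound 1 `O=C(Nc1ccccc1)Nc1cccc(CNc2nccnc2Cl)c1`: 15600 nM
- compound 2 `CN(C)c1ccc(NC(=O)Nc2cccc(CNc3nccnc3Cl)c2)cc1`: > 40000 nM, a limit of the assay and not a number
- compound 3 `O=C(Nc1cccc(Cl)c1)Nc1cccc(CNc2nccnc2Cl)c1`: 9140 nM

Compound 3 has the lowest of the two true numbers, but compound 1 lies within the scatter of it, as the chloro swap shows: a 1.7-fold lower number from compound 1 to compound 3 (0.23 log units; within the scatter). Against the limit compound, the picture is clearer: an at least 4.3-fold lower number from compound 2 to compound 3 (0.64 log units; beyond the scatter).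

Compound 4 `O=C(Nc1cccc(CNc2nccnc2Cl)c1)Nc1ccc(Cl)cc1Cl` carries 2,4-dichlorophenyl in place of 3-chlorophenyl on an amide-type nitrogen. The nearest guide is the chloro step to compound 3, a 1.7-fold lower number from compound 1 to compound 3 (0.23 log units; within the scatter), which stayed small. The dimethylamino step, an at least 2.5-fold higher number from compound 1 to compound 2 (0.40 log units; beyond the scatter), was larger, but it brought in a different group and so bears less on this change. A further chloro change is therefore expected to do little in this assay.

The expected step is a 1.3-fold lower number from compound 3 to compound 4 (0.12 log units; within the scatter), which would not stand beyond the scatter. The estimate for compound 4 is 7000 nM, with a range of 2500 nM to 20000 nM.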

Compound 4, half-maximal inhibitory concentration: 7230 nM
Compound 4: the middle estimate sits 1.0-fold (0.01 log units) below what was measured, and the stated range covers the measured number.
By their numbers in this assay, from the lowest: compounds 4, 3 and 1 (each within the scatter of the next, the first and the last beyond it). At a limit, above all of these: compound 2.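

Swapping 3-chlorophenyl for 2,4-dichlorophenyl on the amide-type nitrogen shows that a second chlorine adds little in this assay, with a 1.3-fold lower number from compound 3 to compound 4 (0.10 log units; within the scatter), yet the dichloro ring is the first chlorinated ring to separate from the plain phenyl ring, with a 2.2-fold lower number from compound 1 to compound 4 (0.33 log units; beyond the scatter), which the single chlorine of compound 3 did not do. The gap to the dimethylamino compound widens slightly on paper, with an at least 5.5-fold lower number from compound 2 to compound 4 (0.74 log units; beyond the scatter), but this step gives only a lower bound on the true size. Compound 2 is a limit of the assay and not a number: the limit of > 40000 nM in this assay, at which 1 of the 4 values shown sits.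

It remains open which of the two chlorines in 2,4-dichlorophenyl accounts for the step from compound 1. Going by these compounds, it is also open how this ring would behave with a methyl, a methoxy or a carboxylic acid in place of chlorine.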